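The source may report more compounds than this note shows. Statements on the series, on what has been measured and on what is new or still open speak of the compounds shown alone.

Compound 1 `CN(C)CCN(CCN(C)C)c1ccc(C(=O)N2CCc3ccc(OS(N)(=O)=O)cc3C2)cc1`: 15.9%
Compound 2 `NS(=O)(=O)Oc1ccc2c(c1)CN(C(=O)c1cccc(N3CCN(Cc4ccccc4)CC3)c1)CC2`: 23.7%

In an assay on HEK293 cells for inhibition of Steryl-sulfatase (Homo sapiens), tested at 1 uM (on this read-out higher numbers stand for a stronger effect at the one concentration tested and lower numbers for a weaker effect), compound 1 gives 15.9%, and compound 2 gives 23.7%; the two numbers sit within the scatter of each other, so neither stands apart. Compound 3 `CCCN(Cc1ccccc1)c1ccc(C(=O)N2CCc3ccc(OS(N)(=O)=O)cc3C2)cc1` differs from compound 1 in one place: benzyl(propyl)amino in place of bis(2-(dimethylamino)ethyl)amino on an aromatic carbon. Among the compounds with values here, no measured pair shows what such a change does in this assay, so the step is expected to be a number 4.1 percentage points higher from compound 1 to compound 3 (within the scatter), not beyond the scatter in either direction. Compound 3 is therefore estimated at 20%, with a range from 5% to 40%.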

Compound 3, a percentage reported as inhibition, at one concentration (the size of the read-out at that concentration, not a potency): 94.3%
Compound 3: the middle estimate sits 74.3 percentage points below what was measured; the measured number lies above the stated range.
By their numbers in this assay, from the lowest: compounds 1 and 2 (each within the scatter of the next); then compound 3.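

In this assay, the group on an aromatic carbon para to a large group turns out to matter greatly: benzyl(propyl)amino in place of bis(2-(dimethylamino)ethyl)amino gives a number 78.4 percentage points higher from compound 1 to compound 3 (beyond the scatter) at this position. The two groups have the same number of heavy atoms, but the entering one carries a six-membered aromatic ring of carbon only and a single nitrogen. Nothing available accounts for this step. Going by these compounds, whether the benzyl or the propyl part carries the step remains open. So does whether a butyl chain in place of propyl, or a dibenzylamino group, would hold the number.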